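The source may report more compounds than this note shows. Statements on the series, on what has been measured and on what is new or still open speak of the compounds shown alone.

Of the compounds shown here, two of a shared core have been measured so far. Compound 1, `O=C(CN1CCC(c2cccc[n+]2[O-])CC1)NC1CCCCC1`, carries a cyclohexyl amide, and in a functional assay on HEK293 cells for agonist activity at D(4) dopamine receptor (Homo sapiens), read by FLIPR (a higher number here means that more compound is needed for the effect, a lower number that less compound is needed), compound 1 gives 294 nM. Compound 2, `O=C(CN1CCC(c2cccc[n+]2[O-])CC1)Nc1cccc(C(F)(F)F)c1`, carries instead an anilide bearing a trifluoromethyl group, and in this assay compound 2 gives 76 nM. Within the data shown here, of the two numbers known, that of compound 2 is the lower, and the gap to compound 1 lies beyond the scatter of repeated measurements, so compound 2 stands as the better of the pair in this assay.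

Compound 3, `CCc1cccc(NC(=O)CN2CCC(c3cccc[n+]3[O-])CC2)c1`, is the next step. It differs from compound 2 in a single place: ethyl in place of trifluoromethyl on an aromatic carbon. Among the measured compounds shown here, no measured pair shows this exchange, so there is nothing in the data to size the step directly. Ethyl and trifluoromethyl are both small, uncharged groups with neither donor nor acceptor, and compound 3 keeps the anilide that separates compound 2 from compound 1.

Compound 3 is therefore expected to remain close to compound 2, with a step of a 1.6-fold higher number from compound 2 to compound 3 (0.20 log units; within the scatter) that may not exceed the scatter. The estimate for compound 3 in this assay is 120 nM, within a range from 40 nM to 400 nM.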

Compound 3, half-maximal effective concentration: 95 nM
For compound 3 the middle estimate is 1.3-fold (0.10 log units) above the measured one; low and high end bracket the measured number.
By their numbers in this assay, from the lowest: compounds 2 and 3 (each within the scatter of the next); then compound 1.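

In this assay, ethyl in place of trifluoromethyl on the aromatic carbon gives a 1.3-fold higher number from compound 2 to compound 3 (0.10 log units; within the scatter), so at this position an all-carbon group and a fluorinated one cannot be told apart beyond the scatter. The other step adds a second comparison: 3-ethylphenyl in place of cyclohexyl on the amide-type nitrogen gives a 3.1-fold lower number from compound 1 to compound 3 (0.49 log units; beyond the scatter), a modest step beyond the scatter, which shows that a number well under that of compound 1 does not require trifluoromethyl on the anilide. Nothing available explains why either exchange has the size it has, or why the two groups on the aromatic carbon give numbers so close together.

The compounds shown leave open how far this position accepts other groups, such as a plain hydrogen, an amine, a carboxylic acid or a longer chain like butyl, any of which might give a step beyond the scatter. They also leave open whether ethyl or trifluoromethyl would give similar numbers at other places on the aromatic ring.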